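Ring Size Change on a Shared Core

The compounds below may be only part of what the source reports. "The series", "measured", "known", "first", "only" and "open" are said of these compounds alone.

For the measured compounds named here, compound 1 `CN(C)c1ccc(C(=O)Nc2ccc(Oc3ncnc4ccsc34)cc2)cc1` is the only compound here with a number: in a functional assay on A549 cells (Homo sapiens) for inhibition, read by MTT assay, with a stated time of 72 h (on this read-out lower numbers stand for stronger inhibition and higher numbers for weaker inhibition), compound 1 gives 20200 nM. Compound 2 `c1cc(N2CCCC2)nc(Nc2ccc(Oc3ncnc4ccsc34)cc2)n1` carries a pyrrolidin-1-yl group on its six-membered aromatic ring with 2 nitrogen, and in this assay compound 2 is reported as "not active" (no number reported), without a single number. Compound 3 `c1ccc(CNc2ccc(Oc3ncnc4ccsc34)cc2)cc1` is likewise reported as "not active" (no number reported). So compound 2 stands without a number, alongside one further entry without one. Compound 4 `c1cc(N2CCCCC2)nc(Nc2ccc(Oc3ncnc4ccsc34)cc2)n1` is still to be tested; it differs from compound 2 by piperidin-1-yl in place of pyrrolidin-1-yl on an aromatic carbon. Going by the values given here, no step between measured compounds is available, so no shift beyond the usual scatter is expected in this assay. The value for compound 4 is therefore estimated at 40000 nM, within 12000 nM to 130000 nM.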

Compound 4, half-maximal inhibitory concentration: 7800 nM
For compound 4 the middle estimate is 5.1-fold (0.71 log units) above the measured one, and the stated range ends above it.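

No step can be read between compound 2 and compound 4: compound 2 has no single number. The compounds shown leave open how large the change from pyrrolidin-1-yl to piperidin-1-yl is. No evidence shown here bears on this result.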